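This account rests on a few compounds, and the source may have more. Where it says the series, first, only, none or still open, it means among the compounds named here.

Compound 1 `CCOc1ccc(-n2nncc2CN2C(=O)C3(C(C#N)=C(N)Oc4c3c3nc5ccccc5nc3c3ccccc43)c3ccccc32)cc1`: in a functional assay on HCT-116 cells (Homo sapiens) for antiproliferative activity, read by MTT assay, with a stated time of 48 h (a lower number here means a stronger inhibitor, a higher number a weaker inhibitor), compound 1 reaches only the limit > 50000 nM.
Compound 2 `Cc1ccc(Cl)cc1-n1nncc1CN1C(=O)C2(C(C#N)=C(N)Oc3c2c2nc4ccccc4nc2c2ccccc32)c2ccccc21`: in this assay compound 2 likewise reaches only the limit > 50000 nM.

Both measured compounds share one core and differ only in the group on the aromatic nitrogen, and both come out at a limit of the assay, so the step that the two limits leave unreadable from compound 1 to compound 2 cannot be sized. Compound 2 thus stands at the limit of > 50000 nM in this assay, at which 2 of the 2 values shown sit; every value gathered so far is such a limit, and nothing shows how far beneath it either compound might actually lie.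

Compound 3 `N#CC1=C(N)Oc2c(c3nc4ccccc4nc3c3ccccc23)C12C(=O)N(Cc1cnnn1-c1cc(Cl)ccc1Cl)c1ccccc12` takes one further step from compound 2: chloro in place of methyl on an aromatic carbon. Among the compounds with values here, no measured step bears directly on this change, and the single measured step, a step that the two limits leave unreadable from compound 1 to compound 2, is itself unreadable. With every known value sitting at the limit, the expected step that the limit leaves unreadable from compound 2 to compound 3 cannot be read as a movement in either direction, and compound 3 is expected to come out at the limit once more. As an estimate, compound 3 is expected at 60000 nM in this assay, within a range from 15000 nM to 250000 nM.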

Compound 3, half-maximal inhibitory concentration: > 50000 nM
Compound 3 was reported as a limit (the forecaster's own chance of this, stated with the estimate: 85%); the middle value does not contradict the limit.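

No step among compound 1, compound 2 and compound 3 can be read, since each value is a limit and not a number: the limit of > 50000 nM in this assay, at which 3 of the 3 values shown sit.

The compounds shown leave open whether changing the group on the aromatic nitrogen of the shared core alters activity in this assay at all, and where the true value of each compound lies.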